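This account rests on a few compounds, and the source may have more. Where it says the series, first, only, none or still open, it means among the compounds named here.

Three compounds have so far been measured in an assay on HEK293 cells for activation of Kir3.1/Kir3.2 (Homo sapiens), read by thallium flux; on this read-out lower numbers stand for smaller maximal responses and higher numbers for larger maximal responses:

Compound 1, `O=C(Cn1nnc(-c2ccccc2)n1)Nc1cc(C2CC2)nn1C1CCCCC1`: 45%
Compound 2, `Cc1cc(NC(=O)Cn2nnc(-c3ccccc3)n2)n(-c2ccccc2)n1`: 66%
Compound 3, `Cc1cc(NC(=O)Cn2nnc(-c3ccccn3)n2)n(C2CCCCC2)n1`: 81%

Compound 3 gives the highest of these three numbers. Compound 2 stands closest to it, yet its number lies lower by a margin beyond the usual scatter, and compound 1 lies furthest, also beyond the scatter. Among the compounds with values here, no two of the measured compounds differ in only one place, so no single structural step has a measured size here.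

Compound 4, `Cc1cc(NC(=O)Cn2nnc(-c3ccc(C(F)(F)F)cc3)n2)n(C2CCCCC2)n1`, has not yet been measured in this assay. It differs from compound 3 in one place: 4-(trifluoromethyl)phenyl in place of pyridin-2-yl on an aromatic carbon. The aryl group on the five-membered aromatic ring with 4 nitrogen is thereby exchanged, while the rest of the molecule is kept.

Within the data shown here, nothing among the measured compounds isolates this exchange, so the direction of the step rests on expectation only. Compound 3, with 81%, sets a high starting point, and a moderate fall from it is expected, a number 16 percentage points lower from compound 3 to compound 4 (beyond the scatter), though a result within the scatter cannot be ruled out. For compound 4 the estimate is 65%, within a range from 42% to 85%.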

Compound 4, largest response reached (Emax), in percent of the reference or control that the assay uses: 94%
The estimate for compound 4 lay 29 percentage points below the measured number; the whole stated range lies below it.
By their numbers in this assay, from the lowest: compound 1; then compound 2; then compound 3; then compound 4.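

Within the data shown here, with this step the aryl group on the five-membered aromatic ring with 4 nitrogen has a measured effect for the first time: in this assay, 4-(trifluoromethyl)phenyl in place of pyridin-2-yl gives a number 13 percentage points higher from compound 3 to compound 4 (beyond the scatter) with the rest of the molecule kept. The exchange removes the ring nitrogen and the hydrogen-bond acceptor of pyridin-2-yl and brings in a larger group of carbon and fluorine, so with this rest of the molecule neither that ring nitrogen nor that acceptor is needed for a high maximal response. Nothing among the data shown explains why the number rises.

As far as these compounds go, this single step changes the ring and adds the trifluoromethyl group together, and compounds 1 and 2, although they carry a phenyl group here, differ from compound 4 in other places as well, so the share of each change remains unknown. Also open, from the compounds shown here alone, is how the response would respond to a chlorine atom, a methoxy group or a carboxylic acid in place of the trifluoromethyl group on this ring.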